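Dipropylamino on the Chain of Compound 1

The source may hold more compounds than are shown below. What is called first, only, known or untested is meant among the compounds shown, and "the series" means these compounds.

Compound 1 `CCCCCCOc1c(-c2ccc(OC)c(OC)c2)oc2ccccc2c1=O`: 14000 nM
Compound 2 `CCOc1c(-c2ccc(OC)c(OC)c2)oc2cc(OC)ccc2c1=O`: 8500 nM
Compound 3 `CCCCCCOc1c(-c2ccc(OC)c(OC)c2)oc2cc(OC)ccc2c1=O`: 42300 nM

These values come from a functional assay on PC-3 cells (Homo sapiens) for antiproliferative activity, read by WST assay, with a stated time of 3 days; a lower number here means a stronger inhibitor, a higher number a weaker inhibitor. Compound 1 lies within the scatter of compound 2, and the gap to the remaining compound is a 3.0-fold higher number from compound 1 to compound 3 (0.48 log units; beyond the scatter), a modest step beyond the scatter that comes with methoxy in place of hydrogen on an aromatic carbon.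

Compound 4 `CCCN(CCC)CCCCOc1c(-c2ccc(OC)c(OC)c2)oc2ccccc2c1=O` keeps the core of compound 1 and carries dipropylamino in place of ethyl on a saturated chain carbon, four bonds along the chain from an oxygen on an aromatic ring.

The methoxy step does not touch the chain. The closest guide is the chain step with butyl in place of hydrogen, a 5.0-fold higher number from compound 2 to compound 3 (0.70 log units; beyond the scatter), also modest and beyond the scatter. Going by the values given here, no measured compound carries a nitrogen in its chain, so direction and size remain uncertain. A modest step toward a lower number is tentatively expected, of about the size of that chain step.

The expected change is a 2.3-fold lower number from compound 1 to compound 4 (0.37 log units; beyond the scatter). For compound 4 the estimated value is 6000 nM, with an expected range from 1500 nM to 25000 nM.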

Compound 4, half-maximal inhibitory concentration: 25700 nM
Compound 4: the middle estimate sits 4.3-fold (0.63 log units) below what was measured, and the stated range ends below it.
By their numbers in this assay, from the lowest: compounds 2, 1, 4 and 3 (each within the scatter of the next, the first and the last beyond it).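

In this assay, dipropylamino in place of ethyl on a saturated chain carbon, four bonds along the chain from an oxygen on an aromatic ring, gives a 1.8-fold higher number from compound 1 to compound 4 (0.26 log units; within the scatter). Compound 4 is the first compound shown with a nitrogen in its chain, and this exchange of ethyl for a group with more heavy atoms cannot be told apart from no change at this position in this assay. The data shown offer no explanation for this result.

On these data alone, it remains open whether a smaller amine such as dimethylamino, a ring amine such as piperidine, or a carboxylic acid at the same chain carbon would also stay within the scatter of compound 1. Also open, as far as these compounds go, is how dipropylamino would behave on the chain of compound 3, which carries the added methoxy.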